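Bromo in place of trifluoromethyl on compound 3

The source may report more compounds than this note shows. Statements on the series, on what has been measured and on what is new or still open speak of the compounds shown alone.

In a functional assay on DU-145 cells (Homo sapiens) for inhibition, read by trypan blue exclusion, with a stated time of 96 h (a lower number here means a stronger inhibitor of growth, a higher number a weaker inhibitor of growth), compound 1 `O=C(O)c1ccc(C(=O)/C(=C\c2ccc(O)c([N+](=O)[O-])c2)SCc2ccc(Br)cc2)cc1` gives 50000 nM. Compound 2 `O=C(O)c1ccc(C(=O)/C(=C\c2ccc([N+](=O)[O-])c(O)c2)SCc2ccc(Br)cc2)cc1` gives 10000 nM. Compound 3 `O=C(O)c1ccc(C(=O)/C(=C\c2ccc(Cl)c([N+](=O)[O-])c2)SCc2ccc(C(F)(F)F)cc2)cc1` gives 1000 nM, the lowest of the three numbers and clear of both others beyond the scatter.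

Compound 4 `O=C(O)c1ccc(C(=O)/C(=C\c2ccc(Cl)c([N+](=O)[O-])c2)SCc2ccc(Br)cc2)cc1` keeps compound 3 unchanged except for bromo in place of trifluoromethyl on an aromatic carbon, para to a large group: bromo in place of trifluoromethyl on an aromatic carbon.

Going by the values given here, the only measured step between single-place neighbours is a 5.0-fold lower number from compound 1 to compound 2 (0.70 log units; beyond the scatter). It is modest, but it lies at a different place in the structure and gives no direct size for this change. Compound 2, at 10000 nM, carries the 4-bromobenzyl group of compound 4, yet it also differs from compound 3 elsewhere, so its higher number cannot be assigned to the bromo. This supports only a slight lean toward a higher number in this assay, and no step beyond the scatter is expected.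

The expected change is a 1.5-fold higher number from compound 3 to compound 4 (0.18 log units; within the scatter). For compound 4 the estimated value is 1500 nM, with an expected range of 500 nM to 5000 nM.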

Compound 4, concentration for 50% growth inhibition: 500 nM
For compound 4 the middle estimate is 3.0-fold (0.48 log units) above the measured one; the measured number falls inside the stated range.
By their numbers in this assay, from the lowest: compounds 4 and 3 (each within the scatter of the next); then compound 2; then compound 1.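

In this assay, 4-bromobenzyl in place of 4-(trifluoromethyl)benzyl gives a 2.0-fold lower number from compound 3 to compound 4 (0.30 log units; within the scatter), so this position does not separate the two groups when the 4-chloro-3-nitrophenyl group is present. With the 4-bromobenzyl group held fixed, the other aryl group carries the large steps: 4-chloro-3-nitrophenyl in place of 3-hydroxy-4-nitrophenyl gives a 20-fold lower number from compound 2 to compound 4 (1.30 log units; beyond the scatter), and chloro in place of hydroxy on an aromatic carbon gives a 100-fold lower number from compound 1 to compound 4 (2.00 log units; beyond the scatter). No available evidence accounts for either the absence of a clear difference at the benzyl group or the large steps at the other aryl group.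

The compounds shown leave open whether bromo and trifluoromethyl stay within the scatter of each other when the aryl group carries hydroxy and nitro, since the only direct pair has the 4-chloro-3-nitrophenyl group. They also leave open how far this position tolerates other groups on the same aromatic carbon, such as an amine, a nitrile or a methoxy group.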